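Curcumin-type enaminones: branched butyl on the nitrogen

The source may hold more compounds than are shown below. What is called first, only, known or untested is meant among the compounds shown, and "the series" means these compounds.

Measured so far:
- compound 1, `COc1cc(/C=C/C(=O)/C=C(/C=C/c2ccc(OC(C)=O)c(OC)c2)NC2CCCCC2)ccc1OC(C)=O` — 62%
- compound 2, `CCC(C)NC(=C\C(=O)/C=C/c1ccc(O)c(OC)c1)/C=C/c1ccc(O)c(OC)c1` — 66%

Among the compounds with values here, in a functional assay on Caco-2 cells (Homo sapiens), read by fluorescence, tested at 10 uM (on this read-out lower numbers stand for a stronger effect and higher numbers for a weaker effect at the one concentration tested), compound 2 gives 66%; the only comparison available is compound 1, whose value in this assay is 62%, and the two numbers lie within the scatter of each other. Compound 3, `COc1cc(/C=C/C(=O)/C=C(/C=C/c2ccc(O)c(OC)c2)NCC(C)C)ccc1O`, is not yet measured. It differs from compound 2 by isobutyl in place of sec-butyl on an amine nitrogen. Within the data shown here, no measured step reaches beyond the scatter, so the expectation for the step from compound 2 to compound 3 is none beyond the scatter: a number 1 percentage points lower from compound 2 to compound 3 (within the scatter). In this assay compound 3 is expected to give about 65%, with a range from 50% to 80%.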

Compound 3, a percentage reported as activity, at one concentration (the size of the read-out at that concentration, not a potency): 74%
Beside the measured number, compound 3's estimate is 9 percentage points below it; the measured number falls inside the stated range.
By their numbers in this assay, from the lowest: compounds 1, 2 and 3 (each within the scatter of the next, the first and the last beyond it).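

In this assay, within the data shown here, isobutyl in place of sec-butyl on an amine nitrogen reads a number 8 percentage points higher from compound 2 to compound 3 (within the scatter) and is the first step that alters this position alone. At this position, the two butyl isomers, with the same atoms joined differently, are not told apart by this read-out. No evidence on the origin of this result is available.

Still open, going by these compounds, is whether a substituent of another kind on this nitrogen, such as a longer chain, a benzyl group or a carboxylic acid, gives a step beyond the scatter. Also open, on these data alone, is whether isobutyl and sec-butyl remain indistinguishable with the acetate esters of compound 1 in place of the free phenols.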